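A few compounds are considered here, and "the series" means these few. Any claim that something is new, unique, unknown or untested is made for them only; others in the source may bear on it.

Measured compounds:

Compound 1 `CNC(=O)c1cc(C(=O)N[C@H]2CC[C@H](O)CC2)c([C@@H](C)c2ccccc2Cl)o1` — in a physicochemical assay for solubility, read by HPLC, in simulated intestinal fluid, with a stated time of 16 h, at pH 6.5 (a lower number here means a less soluble compound, a higher number a more soluble compound), compound 1 gives > 1000 ug/mL, which is a limit of the assay rather than a number.

Compound 2 `CC[C@@H](c1ccccc1)n1nc(C(=O)NC)cc1C(=O)N[C@H]1CC[C@H](O)CC1` — in this assay compound 2 gives > 1000 ug/mL, also a limit rather than a number.

Both measured compounds therefore stand at the same place: compound 1 sits at the limit of > 1000 ug/mL in this assay, at which 2 of the 2 values shown sit. No ordering between compound 1 and compound 2 can be read from these two limits, only that neither was resolved as a number.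

Compound 3 `CNC(=O)c1cc(C(=O)N[C@H]2CC[C@H](O)CC2)c([C@@H](C)c2cccc(Cl)c2)o1` differs from compound 1 in one place: 3-chlorophenyl in place of 2-chlorophenyl on a saturated chain carbon bound to an aromatic carbon and a saturated chain carbon. The two structures hold the same atoms, joined differently; the chlorine simply sits elsewhere on the same ring.

For the measured compounds named here, no measured pair shows this particular change, so the expectation rests on compound 1 alone. The step of a number no higher from compound 1 to compound 3 (the limit leaves the size open) is expected to be none beyond the usual scatter. Compound 3 is therefore expected to give about 1000 ug/mL, somewhere between 500 ug/mL and 2000 ug/mL, and most likely to be reported once more as a limit rather than a number.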

Compound 3, solubility: 408 ug/mL
For compound 3 the middle estimate is 2.5-fold (0.39 log units) above the measured one; the whole stated range lies above it.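

In this assay, 3-chlorophenyl in place of 2-chlorophenyl, on a saturated chain carbon bound to an aromatic carbon and a saturated chain carbon, gives an at least 2.4-fold lower number from compound 1 to compound 3 (0.38 log units; beyond the scatter). For the compounds shown here, the two compounds hold the same atoms, so the place of the chlorine on the ring is the only thing that separates them, and this small rearrangement is enough to produce a step beyond the usual scatter, which the earlier compounds could not show. Compound 3 is also the first compound here to give a number rather than a limit, which means that this position can now be followed on a measured scale, where before there was only a ceiling: the limit of > 1000 ug/mL in this assay, at which 2 of the 3 values shown sit.

The full size of the step stays open, as does the cause of it. Compound 1 gives only a limit, and nothing shown separates one possible explanation from another. Also open, as far as these compounds go, is how the reading would respond to a different group at this place, such as an amine or a carboxylic acid in place of the chlorine, or to a chlorine added to the phenyl ring of compound 2.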